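The source may hold more compounds than are shown below. What is called first, only, known or untested is meant among the compounds shown, and "the series" means these compounds.

In a functional assay on HeLa cells (Homo sapiens) for inhibition, read by CCK-8 assay, with a stated time of 48 h (a higher number here means a weaker inhibitor, a lower number a stronger inhibitor), compound 1 `COc1cc(-c2ccnc3cc(-c4ccc(Cl)cc4)nn23)cc(OC)c1OC` reads 1490 nM and compound 2 `COc1cc(-c2ccnc3cc(-c4ccc(C(F)(F)F)cc4)nn23)cc(OC)c1OC` reads 1840 nM after the same treatment. Going by the values given here, compound 2 thus stands level with compound 1, the only other measured member of the series. Compound 3 `COc1cc(-c2ccnc3cc(-c4ccc(N(C)C)cc4)nn23)cc(OC)c1OC` is not yet measured. It differs from compound 2 in having dimethylamino in place of trifluoromethyl on an aromatic carbon, para to a large group dimethylamino in place of trifluoromethyl on an aromatic carbon on the shared core. Among the compounds with values here, one measured step bears on this change: trifluoromethyl in place of chloro, at a 1.2-fold higher number from compound 1 to compound 2 (0.09 log units; within the scatter) for the same aromatic carbon. That step is a single pair and does not involve dimethylamino, so the guidance is thin and the range must stay wide. The expected move is a 1.2-fold lower number from compound 2 to compound 3 (0.06 log units; within the scatter) and no shift beyond the scatter is anticipated. For compound 3 the estimated value is 1600 nM with an expected range of 600 nM to 4500 nM in this assay once measured.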

Compound 3, half-maximal inhibitory concentration: 378 nM
Estimate against measurement, compound 3: 4.2-fold (0.63 log units) above; the whole stated range lies above it.
By their numbers in this assay, from the lowest: compound 3; then compounds 1 and 2 (each within the scatter of the next).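

On the aromatic carbon para to a large group, chloro and trifluoromethyl had not separated, but this position does respond to the substituent: in this assay, dimethylamino in place of trifluoromethyl gives a 4.9-fold lower number from compound 2 to compound 3 (0.69 log units; beyond the scatter), and dimethylamino in place of chloro gives a 3.9-fold lower number from compound 1 to compound 3 (0.60 log units; beyond the scatter). Both steps lie beyond the scatter, so compound 3 is the strongest inhibitor of the three in this assay, and the two earlier substituents offer no hint of this shift. Nothing available accounts for the difference.

The compounds shown leave open whether the lower number is particular to dimethylamino or extends to other groups on the same aromatic carbon, such as an unsubstituted amine, a methoxy group or a morpholine ring. They also leave open whether a longer chain on the nitrogen, such as diethylamino, would keep the shift.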